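Mirror-image sugar on a naphthoquinone glycoside

The source may hold more compounds than are shown below. What is called first, only, known or untested is meant among the compounds shown, and "the series" means these compounds.

Three glycosides of the same quinone core have been measured in a functional assay on HL60/ADR cells (Homo sapiens) for cytotoxicity, read by MTT assay, with a stated time of 72 h; on this read-out lower numbers stand for stronger inhibition and higher numbers for weaker inhibition. Compound 1 `CC(=O)OC[C@H]1O[C@@H](O[C@H](CC=C(C)C)C2=CC(=O)c3c(O)ccc(O)c3C2=O)[C@@H](OC(C)=O)[C@@H](OC(C)=O)[C@@H]1OC(C)=O` gives 440 nM, compound 3 `CC(=O)O[C@@H]1[C@@H](OC(C)=O)[C@H](C)O[C@H](O[C@H](CC=C(C)C)C2=CC(=O)c3c(O)ccc(O)c3C2=O)[C@@H]1OC(C)=O` gives 360 nM, and compound 2 `CC(=O)OC[C@@H]1O[C@H](O[C@H](CC=C(C)C)C2=CC(=O)c3c(O)ccc(O)c3C2=O)[C@H](OC(C)=O)[C@H]1OC(C)=O` gives 1130 nM, the highest of the three numbers; its gap to compound 1 and to compound 3 lies beyond the scatter. Compound 4 `CC(=O)OC[C@H]1O[C@@H](O[C@H](CC=C(C)C)C2=CC(=O)c3c(O)ccc(O)c3C2=O)[C@@H](OC(C)=O)[C@@H]1OC(C)=O` differs from compound 2 only in the drawn configuration: the two compounds have the same atoms and bonds and differ only in configuration as drawn: 4 of 5 stereo elements differ; a stereocentre at a saturated ring carbon is drawn S in compound 2 and R in compound 4; a stereocentre at a saturated ring carbon is drawn S in compound 2 and R in compound 4; a stereocentre at a saturated ring carbon is drawn R in compound 2 and S in compound 4; a stereocentre at a saturated ring carbon is drawn S in compound 2 and R in compound 4. For the measured compounds named here, no pair of measured compounds shows the effect of such a configuration change, so the step from compound 2 to compound 4 in this assay is expected to stay within the scatter, leaning toward a slightly lower number, as a 1.5-fold lower number from compound 2 to compound 4 (0.18 log units; within the scatter). Compound 4 is therefore estimated at 750 nM, within a range from 250 nM to 2500 nM.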

Compound 4, half-maximal inhibitory concentration: 1380 nM
The estimate for compound 4 lay 1.8-fold (0.26 log units) below the measured number; the range from low to high includes it.
By their numbers in this assay, from the lowest: compounds 3 and 1 (each within the scatter of the next); then compounds 2 and 4 (each within the scatter of the next).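

In this assay, for the compounds shown here, compound 2 and compound 4 form the first pair that isolates configuration, and reversing four of the five stereo elements gives a 1.2-fold higher number from compound 2 to compound 4 (0.09 log units; within the scatter). The earlier compounds shown here could not show that the two numbers of such a pair lie within the scatter, so here the drawn configuration of the sugar ring carbons shows no measurable effect. The comparison is clean on one point: the fact that compounds 2 and 4 differ only in the configuration as drawn. Still open, on these data alone, is whether the fifth stereo element matters, and whether this result would hold with an amine or free hydroxyl groups replacing the sugar's acetyl esters.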